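Propyl in Place of Amino on the Amide Nitrogen

The source may report more compounds than this note shows. Statements on the series, on what has been measured and on what is new or still open speak of the compounds shown alone.

Compound 1 `NNC(=O)c1c(NC(=O)NS(=O)(=O)c2ccccc2)sc2c1CCCCC2` and compound 2 `O=C(Nc1sc2c(c1C(=O)NNc1ccc(Br)cc1)CCCCC2)NS(=O)(=O)c1ccccc1` share the same core and have both been tested in a functional assay on cells (Melanoma cell, Homo sapiens) for inhibition, with a stated time of 48 h; a lower number here means a stronger inhibitor of growth, a higher number a weaker inhibitor of growth. Compound 1 gives 4500 nM and stands as the lower of the two numbers, while compound 2 gives 31300 nM. Among the measured compounds shown here, the one measured step, a 7.0-fold higher number from compound 1 to compound 2 (0.84 log units; beyond the scatter), shows that attaching a 4-bromophenyl to the amine nitrogen makes the compound a weaker inhibitor of growth, by a modest amount.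

Compound 3 `CCCNC(=O)c1c(NC(=O)NS(=O)(=O)c2ccccc2)sc2c1CCCCC2` has not yet been measured. It differs from compound 1 in one place: propyl in place of amino on an amide-type nitrogen. This is a different kind of change from the measured one: the amino group is removed rather than substituted, and a propyl chain takes its place on the amide-type nitrogen. For the measured compounds named here, the step of a 7.0-fold higher number from compound 1 to compound 2 (0.84 log units; beyond the scatter) bears on it only loosely, showing that altering this part of compound 1 weakened inhibition; no measured pair shows what removing the amino group does. A weakening of similar or smaller size is therefore expected, with a step within the scatter also possible. Compound 3 is expected to give 8000 nM, within 2500 nM to 25000 nM, meaning an expected step of a 1.8-fold higher number from compound 1 to compound 3 (0.25 log units; within the scatter).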

Compound 3, concentration for 50% growth inhibition: 65300 nM
For compound 3 the middle estimate is 8.2-fold (0.91 log units) below the measured one; the measured number lies above the stated range.
By their numbers in this assay, from the lowest: compound 1; then compound 2; then compound 3.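

In this assay, the amide-type nitrogen proves more sensitive to this change than the earlier pair could show: replacing amino with propyl gives a 15-fold higher number from compound 1 to compound 3 (1.16 log units; beyond the scatter), a large loss of growth inhibition. Compound 3 also falls behind the compound carrying (4-bromophenyl)amino, with a 2.1-fold higher number from compound 2 to compound 3 (0.32 log units; beyond the scatter), so among these three compounds the unsubstituted amino group of compound 1 gives the strongest inhibitor, and both replacements weaken inhibition. The swap removes a nitrogen with one hydrogen-bond donor and one acceptor and introduces three carbons with neither, but no supporting measurement explains the loss.

These compounds cannot separate the effect of losing the amino nitrogen from the effect of adding the propyl chain, since the two happen together in compound 3. A plain hydrogen, a methyl group or a hydroxyl group on the same nitrogen would help to show which of the two matters more, and whether any group other than amino can keep the inhibition seen with compound 1.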